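Aryl swap on the two-carbon chain: compound 3 to compound 4

The source may hold more compounds than are shown below. What is called first, only, known or untested is meant among the compounds shown, and "the series" means these compounds.

Of the compounds shown here, three on a shared core have been measured in an in vitro assay on cells for displacement of a labelled ligand from thyroid hormone receptor beta (Homo sapiens), with a stated time of 48 h; a higher number here means a weaker inhibitor, a lower number a stronger inhibitor. Compound 1 `Cc1cc(NC(=O)CC(=O)O)c2c(c1Oc1ccc(O)c(CC(C)C)c1)CCC2` gives 39.9 nM; compound 2 `Cc1cc(NC(=O)CC(=O)O)c2c(c1Oc1ccc(O)c(CCCc3ccccc3)c1)CCC2` gives 223 nM; compound 3 `Cc1cc(NC(=O)CC(=O)O)c2c(c1Oc1ccc(O)c(CCc3ccccc3Cl)c1)CCC2` gives 30 nM. Compound 3 carries the lowest of the three numbers, with compound 1 nearest and compound 2 furthest. The steps are a 5.6-fold higher number from compound 1 to compound 2 (0.75 log units; beyond the scatter), a 1.3-fold lower number from compound 1 to compound 3 (0.12 log units; within the scatter) and a 7.4-fold lower number from compound 2 to compound 3 (0.87 log units; beyond the scatter).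

Compound 4 `Cc1cc(NC(=O)CC(=O)O)c2c(c1Oc1ccc(O)c(CCc3cccc(O)c3)c1)CCC2` differs from compound 3 by 3-hydroxyphenyl in place of 2-chlorophenyl on a saturated chain carbon, two bonds along the chain from an aromatic carbon. For the measured compounds named here, the step bearing on this is a 7.4-fold lower number from compound 2 to compound 3 (0.87 log units; beyond the scatter), the only change on the same saturated chain carbon, and it was modest; a 1.3-fold lower number from compound 1 to compound 3 (0.12 log units; within the scatter) shows that a larger group here can also leave this assay unchanged. Going by the values given here, no measured step exchanges one substituted phenyl for another, so the direction is open; a change no larger than modest is expected, most likely toward compound 2. Compound 4 is expected to give 60 nM, within 20 nM to 180 nM. The expected step is a 2.0-fold higher number from compound 3 to compound 4 (0.30 log units; within the scatter).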

Compound 4, inhibition constant: 81.3 nM
Compound 4: the middle estimate sits 1.4-fold (0.13 log units) below what was measured; the range from low to high includes it.
By their numbers in this assay, from the lowest: compounds 3 and 1 (each within the scatter of the next); then compound 4; then compound 2.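

In this assay, for the compounds shown here, the first exchange of one substituted phenyl for another at this position is not silent: 3-hydroxyphenyl in place of 2-chlorophenyl gives a 2.7-fold higher number from compound 3 to compound 4 (0.43 log units; beyond the scatter) with the two-carbon chain unchanged, so the aryl group itself moves the number. Compound 4 also stands apart from both other neighbours, with a 2.7-fold lower number from compound 2 to compound 4 (0.44 log units; beyond the scatter) and a 2.0-fold higher number from compound 1 to compound 4 (0.31 log units; beyond the scatter) in the same series, so groups of this size on the chain do not settle at one level. No measurement shown bears on the cause of these steps.

The swap changes both the substituent and its place on the ring, so the two contributions cannot be separated here. An unsubstituted 2-phenylethyl, 3-chlorophenyl or 2-hydroxyphenyl on the same chain would divide them, and an amine or a carboxylic acid on that ring remains an open case.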